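The source may report more compounds than this note shows. Statements on the series, on what has been measured and on what is new or still open speak of the compounds shown alone.

Measured compounds:

- Compound 1, `COC(=O)C1=C(C)NC(=O)NC1c1cccs1`: in an assay on membranes from HeLa cells for displacement of a labelled ligand from adenosine receptor A3 (Homo sapiens), read by scintillation counting, with a stated time of 180 min, tested at 1 uM (on this read-out lower numbers stand for less inhibition and higher numbers for more inhibition at the one concentration tested (going by the name of the read-out)), compound 1 gives 3%.
- Compound 2, `CC1=C(C(=O)NC(C)C)C(c2cccs2)NC(=O)N1`: in this assay compound 2 gives 1%.

Both numbers sit close to the bottom of the scale, and the two compounds lie within the usual scatter of each other, so neither can be set apart from the other on these readings. Going by the values given here, the one change measured so far, isopropylamino in place of methoxy on a carbonyl carbon, gave a number 2 percentage points lower from compound 1 to compound 2 (within the scatter), which amounts to no real movement.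

Compound 3, `CC1=C(C(=O)OC2CCCC2)C(c2cccs2)NC(=O)N1`, has not yet been measured. It differs from compound 2 by cyclopentyloxy in place of isopropylamino on a carbonyl carbon. This change sits on the same carbonyl carbon that was altered between compound 1 and compound 2, and that earlier swap of the group on this carbon left the reading essentially flat. Among the compounds with values here, with only that one step to go on, the expectation for the step from compound 2 to compound 3 in this assay is no change beyond the scatter, estimated as a number 2 percentage points higher from compound 2 to compound 3 (within the scatter). On that basis compound 3 is expected to give about 3%, with a range from -7% to 13%.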

Compound 3, a percentage reported as inhibition, at one concentration (the size of the read-out at that concentration, not a potency): 1%
Compound 3: middle estimate off by 2 percentage points, on the high side, and the stated range covers the measured number.
By their numbers in this assay, from the lowest: compounds 2, 3 and 1 (each within the scatter of the next).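

Across the three compounds, the carbonyl carbon in this assay has now carried three different groups, and the number has stayed near the bottom of the scale. Cyclopentyloxy in place of isopropylamino on this carbon gives a first view of a swap that brings in a five-membered carbon ring and exchanges nitrogen for oxygen (no change at the digits printed from compound 2 to compound 3 (within the scatter)), while the ester-to-ester comparison, cyclopentyl in place of methyl on the oxygen, reads the same way (a number 2 percentage points lower from compound 1 to compound 3 (within the scatter)). So neither the amide-to-ester swap nor the larger ring-bearing group lifts the reading out of the scatter, and no information in hand explains this flat result.

Since all three numbers sit so low, they cannot show whether this carbonyl carbon matters for the reading or whether the shared core simply does little at this single concentration. A carboxylic acid, a primary amine or a longer alkyl chain on this carbon could still behave differently, and the compounds shown say nothing about changes elsewhere on the core.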